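Carbamoyl in place of fluoro on the aryl ring

This account rests on a few compounds, and the source may have more. Where it says the series, first, only, none or still open, it means among the compounds named here.

Compound 1 `COCc1ccccc1C1Cc2nccn2C1` — in a functional assay on CHO cells for agonist activity at Alpha-1A adrenergic receptor (Homo sapiens), read by FLIPR and calcium flux (on this read-out lower numbers stand for an effect already at smaller amounts and higher numbers for an effect only at larger amounts of compound), compound 1 gives 82 nM
Compound 2 `Fc1ccccc1C1Cc2nccn2C1` — compound 2 gives 42 nM
Compound 3 `c1ccc(C2Cc3nccn3C2)cc1` — compound 3 gives 83 nM; 73 nM; > 10000 nM; 70 nM (4 entries)

In this assay compound 2 stands at the lowest of the two single numbers, with compound 1 nearest, and the step of a 2.0-fold lower number from compound 1 to compound 2 (0.29 log units; within the scatter) between them. One of the several entries of compound 3 is a limit of the assay rather than a number. The remaining entries of compound 3 sit near compound 1, as the record the several entries of compound 3 in this assay, 83 nM; 73 nM; > 10000 nM; 70 nM (4 entries) shows.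

Compound 4 `NC(=O)c1ccccc1C1Cc2nccn2C1` is not yet measured. It differs from compound 2 by carbamoyl in place of fluoro on an aromatic carbon. Among the compounds with values here, the only measured step that touches the same aromatic carbon is the one from compound 1 to compound 2, which swapped one substituent for another and stayed within the scatter. That step offers little ground for a large move in either direction, so the step from compound 2 to compound 4 in this assay is expected to be small, at most a modest rise in the number, and may well fall within the scatter.

Compound 4 is therefore estimated at 120 nM, with a range from 40 nM to 500 nM, which corresponds to an expected step of a 2.9-fold higher number from compound 2 to compound 4 (0.46 log units; beyond the scatter).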

Compound 4, half-maximal effective concentration: 371 nM
Compound 4: the middle estimate sits 3.1-fold (0.49 log units) below what was measured; the range from low to high includes it.
By their numbers in this assay, from the lowest: compounds 2 and 1 (each within the scatter of the next); then compound 4.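

Carbamoyl is the first group at this aromatic carbon to give a step beyond the scatter in this assay: the change from fluoro gives an 8.8-fold higher number from compound 2 to compound 4 (0.95 log units; beyond the scatter), and the change from methoxymethyl gives a 4.5-fold higher number from compound 1 to compound 4 (0.66 log units; beyond the scatter). The position is therefore not indifferent to what it carries, even though the earlier exchange of methoxymethyl for fluoro gave only a 2.0-fold lower number from compound 1 to compound 2 (0.29 log units; within the scatter). Nothing among the data shown explains why carbamoyl raises the number.

From the compounds shown here alone, what remains open is which part of the carbamoyl group goes with the rise, since the entering group differs from both fluoro and methoxymethyl in several counted features at once, among them the hydrogen-bond donor and the double bond outside aromatic rings. Nor do the compounds shown tell whether an amine, a carboxylic acid, a nitrile or a methyl ester on the same aromatic carbon would follow carbamoyl to a higher number or stay with fluoro and methoxymethyl.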